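The compounds below may be only part of what the source reports. "The series", "measured", "known", "first", "only" and "open" are said of these compounds alone.

Compound 1 `Oc1cccc(-c2cc(-c3cccc(C(F)(F)F)c3)cc(-c3cccc(O)c3)n2)c1`, compound 2 `Oc1ccc(-c2cc(-c3cccc(C(F)(F)F)c3)cc(-c3cccc(O)c3)n2)cc1` and compound 3 `Oc1cccc(-c2cc(-c3ccc(OC(F)(F)F)cc3)cc(-c3cccc(O)c3)n2)c1` share a core that carries two hydroxyphenyl groups and a third aryl group. In a functional assay on T47D cells (Homo sapiens) for inhibition (a higher number here means a weaker inhibitor, a lower number a stronger inhibitor), compound 1 gives 4970 nM, compound 2 gives 2630 nM and compound 3 gives 9820 nM. The change from compound 1 to compound 2 is 4-hydroxyphenyl in place of 3-hydroxyphenyl on an aromatic carbon, and it brings a 1.9-fold lower number from compound 1 to compound 2 (0.28 log units; within the scatter). How the core of compound 3 differs from that of compound 1 is not broken down here; compound 3 stands at the highest of the three numbers, within the scatter of compound 1 and beyond it from compound 2.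

Compound 4 `Oc1ccc(-c2cc(-c3ccc(OC(F)(F)F)cc3)cc(-c3cccc(O)c3)n2)cc1` has not yet been measured in this assay. It differs from compound 3 by 4-hydroxyphenyl in place of 3-hydroxyphenyl on an aromatic carbon, the same kind of change as from compound 1 to compound 2, although the place is meta to a 3-(trifluoromethyl)phenyl group in the first pair and meta to a large group in the second. Since the earlier change gave a step within the scatter, a similar small step is expected for compound 4, namely a 1.8-fold lower number from compound 3 to compound 4 (0.25 log units; within the scatter). Compound 4 is therefore estimated at 5500 nM, between 2500 nM and 12000 nM.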

Compound 4, half-maximal inhibitory concentration: 18900 nM
Compound 4: middle estimate off by 3.4-fold (0.54 log units), on the low side; measured number above the stated range.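

In this assay, the exchange of 3-hydroxyphenyl for 4-hydroxyphenyl on a second core brings a 1.9-fold higher number from compound 3 to compound 4 (0.28 log units; within the scatter). Set beside the earlier step, the change does not carry over as a fixed shift from one core to the other, since the two steps differ by more than the scatter of two such steps: the same change on two cores in this assay, a 1.9-fold lower number (0.28 log units; within the scatter) from compound 1 to compound 2 and a 1.9-fold higher number (0.28 log units; within the scatter) from compound 3 to compound 4, 3.6-fold (0.56 log units) apart, beyond the scatter of two such steps. This does not establish a firm reversal, as each step taken alone lies within the scatter, and two pairs cannot show which difference between the cores, the aryl group bearing trifluoromethyl or the one bearing trifluoromethoxy, sets the gap.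

The compounds shown leave open how the same exchange behaves when the third aryl group carries a nitrile or a carboxylic acid instead. They also leave open what happens when an amine takes the place of the hydroxyl group on the hydroxyphenyl ring that is exchanged here.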